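The source may report more compounds than this note shows. Statements on the series, on what has been measured and on what is new or still open speak of the compounds shown alone.

The study gathers three measured analogues built on a shared core and asks what a fourth will do. Compound 1 `N#C/C(=C\c1c(-c2ccccc2)[nH]c2ccccc12)C(=O)c1ccccc1` carries a benzoyl group on the exocyclic carbon beside the nitrile, and in a functional assay on NCI/ADR-RES cells (Homo sapiens) for inhibition, read by sulforhodamine B assay, with a stated time of 48 h (a higher number here means a weaker inhibitor of growth, a lower number a stronger inhibitor of growth), compound 1 gives 3100 nM. Compound 2 `COc1ccc(-c2[nH]c3ccc(OC)cc3c2/C=C(\C#N)S(=O)(=O)c2ccccc2)cc1` instead bears a phenylsulfonyl group together with two methoxy groups, and in this assay compound 2 gives 494 nM. Compound 3 `COc1ccc2[nH]c(-c3ccccc3)c(C=C(C#N)C#N)c2c1` has a dinitrile terminus and a single methoxy group on the core, and in this assay compound 3 gives 2800 nM.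

On these numbers compound 3 stands second highest of the three. Its nearest neighbour is compound 1, whose value lies within the scatter of that of compound 3, so no order between the two can be read. Compound 2 lies furthest away, with a lower number beyond the scatter.

Compound 4 `COc1ccc(-c2[nH]c3ccc(OC)cc3c2C=C(C#N)C#N)cc1` differs from compound 3 in one place: methoxy in place of hydrogen on an aromatic carbon. Among the measured compounds shown here, no measured pair shows this change alone, so its effect must be estimated. The step from compound 3 to compound 4 in this assay is expected to be modest, toward a slightly lower number, at a 1.4-fold lower number from compound 3 to compound 4 (0.15 log units; within the scatter). Compound 4 is therefore estimated at 2000 nM, within a range from 700 nM to 6000 nM.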

Compound 4, concentration for 50% growth inhibition: 403 nM
For compound 4 the middle estimate is 5.0-fold (0.70 log units) above the measured one; measured number outside the range, below it.
By their numbers in this assay, from the lowest: compounds 4 and 2 (each within the scatter of the next); then compounds 3 and 1 (each within the scatter of the next).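

In this assay, among the compounds shown here, the change from phenyl to 4-methoxyphenyl, with methoxy in place of hydrogen on an aromatic carbon para to a large group, gives a 6.9-fold lower number from compound 3 to compound 4 (0.84 log units; beyond the scatter), a step beyond the scatter, and this is the first sign that this position responds to substitution. With the 4-methoxyphenyl group in place, compound 4 gives 403 nM and compound 2 gives 494 nM, values within the scatter of each other, so no order can be read between the dinitrile terminus and the terminus that carries the phenylsulfonyl group. Nothing at hand explains the size of this step, and it rests on this single pair.

The compounds shown leave open whether a hydroxyl, an ethoxy group or a chlorine at the same place would match methoxy, or whether an amine there would do as well. They also leave open whether the same change from phenyl to 4-methoxyphenyl would give a similar step with the benzoyl terminus of compound 1.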